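The source may hold more compounds than are shown below. What is called first, only, known or untested is meant among the compounds shown, and "the series" means these compounds.

Compound 1 `Oc1cccc(-c2cc(-c3ccco3)cc(-c3ccccc3O)n2)c1` and compound 2 `Oc1ccc(-c2cc(-c3ccco3)cc(-c3ccccc3O)n2)cc1` share one core and differ in a single place: 4-hydroxyphenyl in place of 3-hydroxyphenyl on an aromatic carbon. In a functional assay on T47D cells (Homo sapiens) for cytotoxicity, read by CCK-8 assay (on this read-out higher numbers stand for weaker inhibition and lower numbers for stronger inhibition), compound 1 gives 820 nM. For compound 2 the assay reports only a limit, > 50000 nM, and not a number. The step is an at least 60-fold higher number from compound 1 to compound 2 (1.78 log units; beyond the scatter), a large loss of measurable activity.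

Compound 3 `Oc1ccc(-c2cc(-c3ccoc3)cc(-c3cccc(O)c3)n2)cc1` rests on a different core; how it differs from the core of compound 1 is not broken down here. In this assay compound 3 gives 2610 nM. Compound 4 `Oc1ccc(-c2cc(-c3ccoc3)cc(-c3ccc(O)cc3)n2)cc1` arises from compound 3 by the same kind of change: 4-hydroxyphenyl in place of 3-hydroxyphenyl on an aromatic carbon. The surroundings are not identical, though: in compound 1 the place is meta to a 2-hydroxyphenyl group and meta to a furan-2-yl group, while in compound 3 it is meta to a 4-hydroxyphenyl group and meta to a furan-3-yl group.

Because the step from compound 1 to compound 2 was an at least 60-fold higher number from compound 1 to compound 2 (1.78 log units; beyond the scatter), a similarly large loss is expected for compound 4, a 15-fold higher number from compound 3 to compound 4 (1.19 log units; beyond the scatter). Compound 4 is therefore estimated at 40000 nM, within 8000 nM to 200000 nM. The assay may again report only a limit, (the limit of > 50000 nM in this assay, at which 1 of the 3 values shown sits).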

Compound 4, half-maximal inhibitory concentration: 3460 nM
Beside the measured number, compound 4's estimate is 12-fold (1.06 log units) above it, outside the stated range (below it).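

On the core of compound 3, putting 4-hydroxyphenyl in place of 3-hydroxyphenyl gives a 1.3-fold higher number from compound 3 to compound 4 (0.12 log units; within the scatter) in this assay, so on this core the change has no measurable effect. The same change therefore does not carry over from one core to the other with the same size: the same change on two cores in this assay, an at least 60-fold higher number (1.78 log units; beyond the scatter) from compound 1 to compound 2 and a 1.3-fold higher number (0.12 log units; within the scatter) from compound 3 to compound 4, at least 45-fold (1.66 log units) apart, beyond the scatter of two such steps. On these data alone, this shows that the large loss seen on the core of compound 1 is no general rule for this series, but two pairs do not show how the change behaves on any other core, and the size of the earlier step remains open on one side, as compound 2 is known only through a limit.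

The compounds shown leave open which difference between the two cores decides the outcome: the furan-2-yl against the furan-3-yl group, or the 2-hydroxyphenyl against the 4-hydroxyphenyl group. Also open, as far as these compounds go, is how an amine or a carboxylic acid in place of the hydroxyl group would read in this assay.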